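This account rests on a few compounds, and the source may have more. Where it says the series, first, only, none or still open, it means among the compounds named here.

Of the compounds shown here, three have been measured in a functional assay on HCT-116 cells (Homo sapiens) for inhibition, read by MTT assay, with a stated time of 72 h; on this read-out higher numbers stand for weaker inhibition of growth and lower numbers for stronger inhibition of growth. Compound 1 `CN(C)c1ccc(-c2nc3c(N4CCN(Cc5ccncc5)CC4)c(Br)cnc3[nH]2)cc1` gives 700 nM, compound 2 `Cc1cc(CN2CCN(c3c(Br)cnc4[nH]c(-c5ccc(CN)cc5)nc34)CC2)no1` gives 240 nM, and compound 3 `COc1ccc(-c2nc3c(N4CCN(Cc5cncnc5)CC4)c(Br)cnc3[nH]2)cc1` gives 400 nM. Compound 3 thus holds the second highest of the three numbers; its gap to compound 2 is the nearest and its gap to compound 1 the furthest, and both gaps lie within the usual scatter, so the three compounds cannot be told apart on this read-out. Compound 4 `COc1ccc(-c2nc3c(N4CCN(Cc5cc(C)on5)CC4)c(Br)cnc3[nH]2)cc1` differs from compound 3 by one change: 5-methyl-1,2-oxazol-3-yl in place of pyrimidin-5-yl on a saturated chain carbon bound to an amine nitrogen in a ring. Among the compounds with values here, no measured pair shows what this change does, so no step beyond the scatter is expected from compound 3 to compound 4 in this assay. Compound 4 is therefore estimated at 350 nM, between 150 nM and 900 nM, an expected step of a 1.1-fold lower number from compound 3 to compound 4 (0.06 log units; within the scatter).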

Compound 4, concentration for 50% growth inhibition: 540 nM
Estimate against measurement, compound 4: 1.5-fold (0.19 log units) below; measured number inside the range.
By their numbers in this assay, from the lowest: compounds 2, 3, 4 and 1 (each within the scatter of the next, the first and the last beyond it).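

In this assay, replacing pyrimidin-5-yl with 5-methyl-1,2-oxazol-3-yl on a saturated chain carbon bound to an amine nitrogen in a ring gives a 1.4-fold higher number from compound 3 to compound 4 (0.13 log units; within the scatter), so this six-membered and this five-membered aromatic ring cannot be told apart here. Compound 4 also opens a second comparison: methoxy in place of aminomethyl on an aromatic carbon gives a 2.3-fold higher number from compound 2 to compound 4 (0.35 log units; beyond the scatter), a modest step. Nothing measured here explains either step. The aminomethyl step rests on this single pair. From the compounds shown here alone, whether a carboxylic acid or a longer amine chain on that aromatic carbon would shift the number remains open.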